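Moving the chlorine on the benzyloxy arm: compound 3 to 4

A few compounds are considered here, and "the series" means these few. Any claim that something is new, unique, unknown or untested is made for them only; others in the source may bear on it.

Three compounds share one core and differ only in the ring at the end of the benzyloxy arm. Compound 1 `FC(F)(F)c1ccc(CN2CCN(Cc3cc(-c4ccc(OCc5ccccc5)cc4)on3)CC2)cc1` gives 1700 nM in a functional assay on Huh-7 cells (Homo sapiens) for antiproliferative activity, read by sulforhodamine B assay, with a stated time of 72 h; on this read-out higher numbers stand for weaker inhibition and lower numbers for stronger inhibition. Compound 2 `Cc1cccc(COc2ccc(-c3cc(CN4CCN(Cc5ccc(C(F)(F)F)cc5)CC4)no3)cc2)c1` gives 5000 nM, and compound 3 `FC(F)(F)c1ccc(CN2CCN(Cc3cc(-c4ccc(OCc5ccccc5Cl)cc4)on3)CC2)cc1` gives 1000 nM. Compound 3 has the lowest number of the three, though its gap to compound 1 is within the scatter; its gap to compound 2 is larger, as a 5.0-fold lower number from compound 2 to compound 3 (0.70 log units; beyond the scatter) shows.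

Compound 4 `FC(F)(F)c1ccc(CN2CCN(Cc3cc(-c4ccc(OCc5cccc(Cl)c5)cc4)on3)CC2)cc1` has not been measured. It differs from compound 3 in one place: 3-chlorophenyl in place of 2-chlorophenyl on a saturated chain carbon bound to an oxygen on an aromatic ring.

For the measured compounds named here, two measured steps bear on this. Adding chloro to the plain benzyl ring gave a 1.7-fold lower number from compound 1 to compound 3 (0.23 log units; within the scatter), a shift too small to count. Adding methyl to give the 3-methylphenyl ring gave a 2.9-fold higher number from compound 1 to compound 2 (0.47 log units; beyond the scatter), a worsening beyond the scatter. A substituent on the 3-chlorophenyl ring sits where the methyl of compound 2 sat, so a modest weakening of inhibition is expected for compound 4, though chloro and methyl need not behave alike.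

Compound 4 is therefore expected to give about 1800 nM in this assay, with a plausible range from 800 nM to 4500 nM, an expected step of a 1.8-fold higher number from compound 3 to compound 4 (0.26 log units; within the scatter).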

Compound 4, half-maximal inhibitory concentration: 200 nM
The estimate for compound 4 lay 9.0-fold (0.95 log units) above the measured number; measured number outside the range, below it.
By their numbers in this assay, from the lowest: compound 4; then compounds 3 and 1 (each within the scatter of the next); then compound 2.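

In this assay, where the chlorine sits on the benzyl ring proved to matter more than its mere presence: 3-chlorophenyl in place of 2-chlorophenyl, a swap of the same atoms joined differently, gave a 5.0-fold lower number from compound 3 to compound 4 (0.70 log units; beyond the scatter), whereas adding chlorine as the 2-chlorophenyl ring had given only a 1.7-fold lower number from compound 1 to compound 3 (0.23 log units; within the scatter), a shift within the scatter. The methyl result did not carry over to chlorine, since chloro in place of methyl gave a 25-fold lower number from compound 2 to compound 4 (1.40 log units; beyond the scatter) and chloro in place of hydrogen gave an 8.5-fold lower number from compound 1 to compound 4 (0.93 log units; beyond the scatter), while methyl in place of hydrogen had moved the number the other way, with a 2.9-fold higher number from compound 1 to compound 2 (0.47 log units; beyond the scatter). So the same ring placement can raise or lower the number depending on the group it carries, and nothing shown here offers a reason for these shifts.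

The compounds shown leave open whether a bromine or a methoxy group in place of the chlorine of compound 4 would also give a low number, or whether this result belongs to chlorine alone. They also leave open whether the same ranking would hold in a cell line other than Huh-7.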